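This account rests on a few compounds, and the source may have more. Where it says the series, first, only, none or still open, it means among the compounds named here.

Among the measured compounds shown here, compound 1, `COc1ccc(CS(=O)(=O)/C=C/c2c(OC)cccc2OC)cc1[N+](=O)[O-]`, is the one member of this set with a number in a functional assay on MCF7 cells (Homo sapiens) for cytotoxicity, read by MTT assay, with a stated time of 72 h (on this read-out higher numbers stand for weaker inhibition of growth and lower numbers for stronger inhibition of growth), where compound 1 gives 13700 nM. Compound 2, `COc1ccc(CS(=O)(=O)CC(=O)Nc2c(C)cc(C)cc2C)cc1[N+](=O)[O-]`, reaches only a limit of this assay, > 30000 nM. Compound 3, `COc1ccc(CS(=O)(=O)CC(=O)Nc2c(C)cc(C)cc2C)cc1N`, likewise reaches only a limit, > 30000 nM. The step from compound 2 to compound 3, a step that the two limits leave unreadable from compound 2 to compound 3, is the change (amino in place of nitro on an aromatic carbon), and its size is unreadable because both values sit at the limit of > 30000 nM in this assay, at which 2 of the 3 values shown sit. The difference between the core of compound 1 and the core of compound 2 is not broken down here.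

Compound 4, `COc1ccc(CS(=O)(=O)/C=C/c2c(OC)cccc2OC)cc1N`, differs from compound 1 by amino in place of nitro on an aromatic carbon, which is the same change made from compound 2 to compound 3, at a place described in the same words. For the measured compounds named here, the expected step from compound 1 to compound 4 in this assay is a 1.1-fold higher number from compound 1 to compound 4 (0.04 log units; within the scatter), resting on the unreadable size of a step that the two limits leave unreadable from compound 2 to compound 3 and on the single number given by compound 1. Compound 4 is therefore estimated to give 15000 nM, between 5000 nM and 40000 nM.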

Compound 4, concentration for 50% growth inhibition: 40 nM
Compound 4: the middle estimate sits 380-fold (2.57 log units) above what was measured, outside the stated range (below it).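

In this assay, amino in place of nitro on an aromatic carbon brings a 340-fold lower number from compound 1 to compound 4 (2.53 log units; beyond the scatter), a large step on this core. The same change on the core of compound 2 cannot be read, because compound 2 and compound 3 each give a limit and not a number: the limit of > 30000 nM in this assay, at which 2 of the 4 values shown sit. The series therefore shows the size of this change on one core only, and it shows neither that the step carries over to the other core nor that it fails to do so.

The compounds shown leave open whether the large step belongs to amino in particular, or whether a hydroxyl, a methylamino or a dimethylamino group on the same aromatic carbon would also give a low number on the core of compound 1. They also leave open whether an acetamide at that place would keep or lose the step seen with amino.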